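Sulfonyl ring swap on a quinoline sulfonamide core

A few compounds are considered here, and "the series" means these few. Any claim that something is new, unique, unknown or untested is made for them only; others in the source may bear on it.

Measured compounds:
compound 1 `Cc1ccc2cccc(NS(=O)(=O)c3ccccc3[N+](=O)[O-])c2n1`, 200%
compound 2 `Cc1ccc2cccc(NS(=O)(=O)c3ccccc3N)c2n1`, 250%

In an assay on OCI-Ly3 cells for activation of NF-kappa-B inhibitor alpha (Homo sapiens), read by a luciferase reporter (a higher number here means a larger maximal response, a lower number a smaller maximal response), compound 2 gives 250%, the higher of the two numbers recorded; the nearest is compound 1, which gives 200%. For the measured compounds named here, the one measured step, a number 50 percentage points higher from compound 1 to compound 2 (beyond the scatter), shows that changing a group on the ring attached to the sulfonyl sulfur can move the read-out well beyond the scatter.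

Compound 3 `Cc1ccc2cccc(NS(=O)(=O)c3ccc(Br)s3)c2n1` is not yet measured. It differs from compound 2 by 5-bromothiophen-2-yl in place of 2-aminophenyl on a sulfonyl sulfur. Going by the values given here, no measured step covers a 5-bromothiophen-2-yl ring at this place, so the only guide is that the amino group, whose arrival gave a number 50 percentage points higher from compound 1 to compound 2 (beyond the scatter), is lost. Compound 3 is therefore expected to show a step of a number 60 percentage points lower from compound 2 to compound 3 (beyond the scatter) in this assay. The estimate for compound 3 in this assay is 190%, with a range from 110% to 270%.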

Compound 3, largest response reached (reported as efficacy), in percent of the reference or control that the assay uses: 22%
For compound 3 the middle estimate is 168 percentage points above the measured one; the whole stated range lies above it.
By their numbers in this assay, from the lowest: compound 3; then compound 1; then compound 2.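

In this assay, 5-bromothiophen-2-yl in place of 2-aminophenyl on the sulfonyl sulfur gives a number 228 percentage points lower from compound 2 to compound 3 (beyond the scatter), a much larger move than a number 50 percentage points higher from compound 1 to compound 2 (beyond the scatter), where the six-membered aromatic ring of carbon only stayed and just one of its groups changed. This place therefore tolerates more than small shifts: replacing the whole ring can take the maximal response far down, whereas the earlier step showed only a rise. Nothing available here accounts for the size of the drop.

The compounds shown leave open which part of the change matters most: the loss of the amino group, the sulfur of the new ring or the bromine. An unsubstituted phenyl ring, a thiophen-2-yl ring without bromine, or one carrying an amine instead would each bear on that question.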